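Cytotoxicity notes: 3-fluorophenyl in place of 2-fluorophenyl

This account rests on a few compounds, and the source may have more. Where it says the series, first, only, none or still open, it means among the compounds named here.

All compounds here share one core and differ in the group on the amide-type nitrogen. In an ADME assay on MT4 cells (Homo sapiens) for cytotoxicity, read by MTT assay, with a stated time of 5 days (on this read-out lower numbers stand for higher toxicity in this test and higher numbers for lower toxicity in this test), compound 3 `COc1cc2nc([S+]([O-])CC(=O)Nc3ccccc3F)nc(Nc3c(Cl)cc(/C=C/C#N)cc3Cl)c2cc1OC` gives > 208000 nM, which is a limit of the assay and not a number. Compound 1 `COc1cc2nc([S+]([O-])CC(=O)Nc3ccccc3[N+](=O)[O-])nc(Nc3c(Cl)cc(/C=C/C#N)cc3Cl)c2cc1OC` gives > 199000 nM, also a limit. Within the data shown here, compound 2 `COc1cc2nc([S+]([O-])CC(=O)Nc3cccc(Cl)c3)nc(Nc3c(Cl)cc(/C=C/C#N)cc3Cl)c2cc1OC` gives 68900 nM, the only true number so far.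

The step to compound 4 `COc1cc2nc([S+]([O-])CC(=O)Nc3cccc(F)c3)nc(Nc3c(Cl)cc(/C=C/C#N)cc3Cl)c2cc1OC` is 3-fluorophenyl in place of 2-fluorophenyl on an amide-type nitrogen.

Among the measured compounds shown here, two measured steps bear on it. One is an at least 3.0-fold higher number from compound 2 to compound 3 (0.47 log units; beyond the scatter), with 2-fluorophenyl in place of 3-chlorophenyl. The other is an at least 2.8-fold lower number from compound 1 to compound 2 (0.46 log units; beyond the scatter), with 3-chlorophenyl in place of 2-nitrophenyl. Both lie beyond the scatter, and both are bounded on one side by a limit. For the measured compounds named here, neither isolates the change at hand, since each also swaps the substituent, and no pair here compares 2-fluorophenyl with 3-fluorophenyl directly.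

Compound 2 at 68900 nM is the closest guide, as it also carries its halogen on a 3-substituted phenyl. A modest move towards a lower number is therefore expected in this assay, and compound 4 may still end at a limit. The expected change is an at least 1.8-fold lower number from compound 3 to compound 4 (0.27 log units; that floor lies within the scatter). For compound 4 the estimated value is 110000 nM, with an expected range from 55000 nM to 220000 nM.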

Compound 4, half-maximal cytotoxic concentration: 9550 nM
The estimate for compound 4 lay 12-fold (1.06 log units) above the measured number, and the stated range ends above it.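

Among these compounds, with only the fluoro group moved, 3-fluorophenyl in place of 2-fluorophenyl on the amide-type nitrogen gives in this assay an at least 21-fold lower number from compound 3 to compound 4 (1.33 log units; beyond the scatter), so at this position the place of the fluoro group alone carries a large step, which no earlier pair could show. The 3-fluorophenyl group also reads lower than the 3-chlorophenyl group, with a 7.2-fold lower number from compound 2 to compound 4 (0.86 log units; beyond the scatter), and lower than the 2-nitrophenyl group, with an at least 20-fold lower number from compound 1 to compound 4 (1.31 log units; beyond the scatter), so that among these four compounds the 3-fluorophenyl and 3-chlorophenyl groups give true numbers while the 2-fluorophenyl and 2-nitrophenyl groups give limits, with none going against this. Compound 3 gives a limit and not a number, so the step from it is only a floor: the limit of > 208000 nM in this assay, at which 1 of the 4 values shown sits.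

How far the true values of compound 1 and compound 3 lie past their limits stays open, and with it the full size of these steps, and nothing shown gives a reason for them. Also open, going by these compounds, is whether the low number stays with a halogen on the phenyl ring or also appears with an amine or a carboxylic acid in place of the fluoro group.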